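A few compounds are considered here, and "the series" means these few. Any claim that something is new, unique, unknown or untested is made for them only; others in the source may bear on it.

Measured in a functional assay on MCF7 cells (Homo sapiens) for cytotoxicity, read by sulforhodamine B assay, with a stated time of 48 h; a higher number here means a weaker inhibitor, a lower number a stronger inhibitor:
- compound 1 `O=C(c1cccnc1)c1cc(F)ccc1O`: 27800 nM
- compound 2 `O=C(c1cccnc1)c1cc(Cl)ccc1O`: 29000 nM

For the measured compounds named here, on the numbers so far compound 2 stands level with compound 1, the only step being a 1.0-fold higher number from compound 1 to compound 2 (0.02 log units; within the scatter). Compound 3 `O=C(c1cccnc1)c1cc(Br)ccc1O` differs from compound 2 by bromo in place of chloro on an aromatic carbon. Going by the values given here, the one step that bears on this is the halogen swap at the same aromatic carbon, a 1.0-fold higher number from compound 1 to compound 2 (0.02 log units; within the scatter), which stayed inside the scatter. The step of no change at the digits printed from compound 2 to compound 3 (within the scatter) is therefore expected to show no change beyond the scatter. For compound 3 the estimate in this assay is 29000 nM, with a range of 14000 nM to 60000 nM.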

Compound 3, half-maximal inhibitory concentration: 53500 nM
Compound 3: the middle estimate sits 1.8-fold (0.27 log units) below what was measured, within the range that was stated.
By their numbers in this assay, from the lowest: compounds 1, 2 and 3 (each within the scatter of the next).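

In this assay, for the compounds shown here, the aromatic carbon para to the hydroxy group now carries fluoro, chloro or bromo with no step leaving the scatter: bromo in place of chloro gives a 1.8-fold higher number from compound 2 to compound 3 (0.27 log units; within the scatter), and bromo in place of fluoro gives a 1.9-fold higher number from compound 1 to compound 3 (0.28 log units; within the scatter). Even the swap from fluoro to bromo therefore does not separate the compounds at this position. No available data explain these numbers.

Going by these compounds, whether an amine, a carboxylic acid or a longer chain at this carbon would give a step beyond the scatter remains open. Also open, on these data alone, is how the series responds to a change to the hydroxy group itself.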